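The compounds below may be only part of what the source reports. "The series", "measured", "known", "first", "only" and "open" are said of these compounds alone.

In a functional assay on WI-38 VA13 cells (Homo sapiens) for cytotoxicity (on this read-out lower numbers stand for an effect already at smaller amounts and higher numbers for an effect only at larger amounts of compound), the three measured compounds read:
compound 1 `CC(C)(C)OC(=O)Nc1nc2ccc(NC(=O)c3c(Cl)cccc3Cl)cc2s1`: 0.027 ug/mL
compound 2 `O=C(NCc1ccccc1)Nc1nc2ccc(NC(=O)c3c(Cl)cccc3Cl)cc2s1`: 0.15 ug/mL
compound 3 `CCCCCNc1nc2ccc(NC(=O)c3c(Cl)cccc3Cl)cc2s1`: 0.27 ug/mL

Compound 3 carries the highest number of the three: a 10-fold higher number from compound 1 to compound 3 (1.00 log units; beyond the scatter), whereas a 1.8-fold higher number from compound 2 to compound 3 (0.26 log units; within the scatter). Compound 4 `COc1ccc(Nc2nc3ccc(NC(=O)c4c(Cl)cccc4Cl)cc3s2)cc1` differs from compound 3 by 4-methoxyphenyl in place of pentyl on a nitrogen on an aromatic ring. The two earlier steps are the ones that bear on this change, since both alter the group on the same nitrogen: one was a modest step beyond the scatter, the other stayed within it. Within the data shown here, no measured compound carries an aromatic ring on that nitrogen, so the direction is uncertain and a small step is the safest expectation. Compound 4 is therefore estimated at 0.2 ug/mL, with a range from 0.05 ug/mL to 0.8 ug/mL, which would be an expected 1.4-fold lower number from compound 3 to compound 4 (0.13 log units; within the scatter).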

Compound 4, half-maximal effective concentration: 0.87 ug/mL
The estimate for compound 4 lay 4.4-fold (0.64 log units) below the measured number, outside the stated range (above it).
By their numbers in this assay, from the lowest: compound 1; then compounds 2 and 3 (each within the scatter of the next); then compound 4.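

In this assay, 4-methoxyphenyl on this nitrogen gives the highest number of the series, with a 3.2-fold higher number from compound 3 to compound 4 (0.51 log units; beyond the scatter), a 5.8-fold higher number from compound 2 to compound 4 (0.76 log units; beyond the scatter) and a 32-fold higher number from compound 1 to compound 4 (1.51 log units; beyond the scatter). The step from pentyl shows that two groups without a carbonyl on this nitrogen can also differ beyond the scatter. Nothing shown gives a reason for these steps.

Still open, from the compounds shown here alone, is whether the aromatic ring itself or its methoxy group accounts for the higher number. A plain phenyl group on this nitrogen would help to separate the two.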